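This account rests on a few compounds, and the source may have more. Where it says the series, first, only, none or still open, it means among the compounds named here.

Three compounds of a shared core, differing at two places, have been tested in a functional assay on the whole organism (Hindlimb, strain albino) with Mus musculus as the target, in the maximal electroshock model, with a stated time of 0.5 h; on this read-out lower numbers stand for an effect already at smaller amounts and higher numbers for an effect only at larger amounts of compound. Compound 2 `CC(=O)N1N=C(Nc2nc3ccc(C)cc3s2)CC1c1ccc(Cl)cc1` gives 25.5 umol/kg. Compound 1 `CC(=O)N1N=C(Nc2nc3ccc(C)cc3s2)CC1OC1=CC=C1` gives 160 umol/kg, and compound 3 `CC(=O)N1N=C(Nc2nc3ccc(Cl)cc3s2)CC1c1ccc(Cl)cc1` gives 79.5 umol/kg.

Two single-point changes connect them. The change from compound 2 to compound 1 is a group of 5 heavy atoms (4 carbon, 1 oxygen; one four-membered non-aromatic ring of carbon only) in place of a group of 7 heavy atoms (6 carbon, 1 chlorine; one six-membered aromatic ring of carbon only), on a saturated ring carbon, and it made a step of a 6.3-fold higher number from compound 2 to compound 1 (0.80 log units; beyond the scatter). The change from compound 2 to compound 3 is the difference between the two cores, (chloro in place of methyl on an aromatic carbon), and it made a step of a 3.1-fold higher number from compound 2 to compound 3 (0.49 log units; beyond the scatter). Compound 1 and compound 3 are not connected by a single change; their two values lie within the usual scatter of each other.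

Compound 4 `CC(=O)N1N=C(Nc2nc3ccc(Cl)cc3s2)CC1OC1=CC=C1` is not yet measured. It differs from compound 3 by a group of 5 heavy atoms (4 carbon, 1 oxygen; one four-membered non-aromatic ring of carbon only) in place of a group of 7 heavy atoms (6 carbon, 1 chlorine; one six-membered aromatic ring of carbon only), on a saturated ring carbon. This is the same change as the one from compound 2 to compound 1, and it sits at the same place; only the core is different, as described above. Among the compounds shown, this change occurs twice, once measured and once not.

Because the step of a 6.3-fold higher number from compound 2 to compound 1 (0.80 log units; beyond the scatter) was seen on the core of compound 2, a step of about the same size is expected from compound 3 to compound 4 in this assay, namely a 6.3-fold higher number from compound 3 to compound 4 (0.80 log units; beyond the scatter). This rests on a single measured pair, so the range is kept wide. Compound 4 is therefore estimated at 500 umol/kg, with a likely range from 200 umol/kg to 1300 umol/kg.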

Compound 4, dose for half-maximal effect: 212 umol/kg
Compound 4: the middle estimate sits 2.4-fold (0.37 log units) above what was measured; the range from low to high includes it.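

Within the data shown here, on the core of compound 3 in this assay, the same exchange of the 4-chlorophenyl group gave a 2.7-fold higher number from compound 3 to compound 4 (0.43 log units; beyond the scatter), so the direction seen on the core of compound 2 recurs, and the two steps can be treated as the same within the scatter: the same change on two cores in this assay, a 6.3-fold higher number (0.80 log units; beyond the scatter) from compound 2 to compound 1 and a 2.7-fold higher number (0.43 log units; beyond the scatter) from compound 3 to compound 4, 2.4-fold (0.37 log units) apart, within the scatter of two such steps Chloro in place of methyl, now carried out with the four-membered ring group in place, gave a 1.3-fold higher number from compound 1 to compound 4 (0.12 log units; within the scatter), a step that lies within the scatter on its own, yet it cannot be told apart from the earlier, larger step for this change: the same change on two cores in this assay, a 3.1-fold higher number (0.49 log units; beyond the scatter) from compound 2 to compound 3 and a 1.3-fold higher number (0.12 log units; within the scatter) from compound 1 to compound 4, 2.4-fold (0.37 log units) apart, within the scatter of two such steps The four compounds thus fit both changes carrying over from one core to the other, but with only two pairs per change they do not establish that the steps are equal in size, nor do they show that this would hold on any further core or explain why the steps behave this way.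

From the compounds shown here alone, it remains open whether a plain phenyl, a 4-methoxyphenyl, an amine or a longer alkyl chain on the saturated ring carbon would follow the same trend. Going by these compounds, it is equally open how a methoxy or a nitrile in place of the chloro or methyl on the aromatic carbon would behave.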